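Chain extension on the amino-diol head group

A few compounds are considered here, and "the series" means these few. Any claim that something is new, unique, unknown or untested is made for them only; others in the source may bear on it.

Of the compounds shown here, two of this amino-diol series have been measured in a functional assay on H322 cells (Homo sapiens) for inhibition; a lower number here means a stronger inhibitor, a higher number a weaker inhibitor. Compound 1, `CCCCCCCCCCCCCCCCCC[C@@H](N)[C@@H](O)CO`, carries the longer saturated chain and in this assay gives 24400 nM. Compound 2, `CCCCCCCCCCCCCC[C@H](N)[C@H](O)CO`, carries the shorter chain with the opposite configuration at both stereocentres and in this assay gives 1450 nM. Going by the values given here, compound 2 thus stands at the lowest of the two numbers, and the gap to compound 1 is beyond the scatter; no single-point step links the pair, since they differ in chain length and in configuration at once.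

Compound 3, `CCCCCCCCCCCCCCCCCC[C@H](N)[C@H](O)CO`, keeps the configuration of compound 2 and differs from it by butyl in place of hydrogen on a saturated chain carbon, ten or more bonds along the chain from an amine nitrogen. Among the compounds with values here, no measured step isolates this change. Compound 1, which shares the longer chain, gives 24400 nM, and that figure is taken as a pointer towards weaker inhibition with the longer chain, though its configuration differs. The step from compound 2 to compound 3 is therefore estimated as a 4.1-fold higher number from compound 2 to compound 3 (0.62 log units; beyond the scatter), a loss beyond the scatter. Compound 3 is expected to give 6000 nM, within 2000 nM to 25000 nM.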

Compound 3, half-maximal inhibitory concentration: 1710 nM
Estimate against measurement, compound 3: 3.5-fold (0.55 log units) above, and the stated range ends above it.
By their numbers in this assay, from the lowest: compounds 2 and 3 (each within the scatter of the next); then compound 1.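

In this assay, butyl in place of hydrogen on a saturated chain carbon, ten or more bonds along the chain from an amine nitrogen, gives a 1.2-fold higher number from compound 2 to compound 3 (0.07 log units; within the scatter), so with this configuration the two chain lengths cannot be told apart. The opening pair could not show this, as chain length and configuration differed together there. Inverting both stereocentres at the longer chain gives a 14-fold lower number from compound 1 to compound 3 (1.15 log units; beyond the scatter), and this large step is assigned to configuration alone, due to the following: the fact that compounds 1 and 3 differ only in the configuration as drawn.

On these data alone, the two stereocentres are inverted together in this step, so the share of each stays open, and a compound with only one of them inverted would separate the two. Also open, as far as these compounds go, are whether the step between mirror images has a similar size at the shorter chain, and whether the flat response to chain length extends to a still longer chain or to a chain ending in a carboxylic acid.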